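This account rests on a few compounds, and the source may have more. Where it says the series, first, only, none or still open, it means among the compounds named here.

Measured in an ADME assay on Vero cells (Chlorocebus sabaeus) for cytotoxicity, read by MTT assay, with a stated time of 96 h; a lower number here means that less compound is tolerated, a higher number that more compound is tolerated:
- compound 1 `CC(=O)c1ccc2c(c1)nc(-c1ccc(Cl)cc1)n2C1CCCCC1`: > 100000 nM
- compound 2 `CC(=O)c1ccc2c(c1)nc(-c1ccc(C(F)(F)F)cc1)n2C1CCCCC1`: 35000 nM
- compound 3 `COc1ccc(-c2nc3cc(C(C)=O)ccc3n2C2CCCCC2)cc1`: 30000 nM

Compound 1 has no exact number, only a limit of the assay at > 100000 nM. That makes it the one entry in this small set recorded as the limit of > 100000 nM in this assay, at which 1 of the 3 values shown sits.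

Compound 4 `C/C(=N\NC(N)=O)c1ccc2c(c1)nc(-c1ccc(Cl)cc1)n2C1CCCCC1` keeps the shared core and the chloro group of compound 1. On an aromatic carbon, however, a group of 7 heavy atoms replaces the acetyl: a group of 7 heavy atoms (3 carbon, 3 nitrogen, 1 oxygen; no ring) in place of a group of 3 heavy atoms (2 carbon, 1 oxygen; no ring), on an aromatic carbon.

Within the data shown here, no measured step touches the acetyl, so the evidence here is only indirect. Replacing the chloro group gave an at least 2.8-fold lower number from compound 1 to compound 2 (0.45 log units; beyond the scatter) and an at least 3.3-fold lower number from compound 1 to compound 3 (0.52 log units; beyond the scatter). The step of a 1.2-fold lower number from compound 2 to compound 3 (0.07 log units; within the scatter) stays within the scatter. Both changes made to compound 1 therefore lowered the number, though they involved a different group from the one changing now. On that thin basis, a modest step to a lower number is expected, with a real chance that the result stays at the limit of this assay.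

The estimated step is an at least 1.6-fold lower number from compound 1 to compound 4 (0.22 log units; that floor lies within the scatter).

For compound 4 the expected value is 60000 nM, with an estimated range from 15000 nM to 100000 nM.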

Compound 4, half-maximal cytotoxic concentration: > 100000 nM
Compound 4: no number, only a limit (the forecaster's own chance of this, stated with the estimate: 45%); middle value at least 1.6-fold (0.22 log units) away from the limit.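

Compound 1 and compound 4 both stand at the same limit rather than at a number, so no step between them can be read in this assay: the limit of > 100000 nM in this assay, at which 2 of the 4 values shown sit.

The compounds shown leave open how far beyond that limit each of the two lies, and so whether the group of 7 heavy atoms in place of the acetyl changes tolerance at all.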